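The compounds below may be only part of what the source reports. "The series", "measured", "known", "first", "only" and "open" are said of these compounds alone.

Of the compounds shown here, three sharing one core have so far been measured in a functional assay on HCT-116 cells (Homo sapiens) for inhibition, read by MTT assay, with a stated time of 72 h; a higher number here means a weaker inhibitor, a lower number a stronger inhibitor. Compound 1 `COc1ccc2oc(=O)c(/C=C/C(=O)N3CCC=CC3=O)c(O)c2c1` gives 10000 nM. Compound 2 `O=C1C=CCCN1C(=O)/C=C/c1c(O)c2ccc(Cl)cc2oc1=O` gives 12000 nM, the highest of the three numbers, though its gaps to the other two both lie within the scatter. Compound 3 `O=C1C=CCCN1C(=O)/C=C/c1c(O)c2ccc(F)cc2oc1=O` gives 11000 nM. Among the compounds with values here, the one single-point step among them, a 1.1-fold lower number from compound 2 to compound 3 (0.04 log units; within the scatter), shows that exchanging one halogen for another on that aromatic carbon leaves this assay unchanged within the scatter.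

Compound 4 `O=C1C=CCCN1C(=O)/C=C/c1c(O)c2ccccc2oc1=O` has not yet been measured in this assay. It differs from compound 2 by hydrogen in place of chloro on an aromatic carbon. Within the data shown here, the only step that bears on this change is the halogen exchange, a 1.1-fold lower number from compound 2 to compound 3 (0.04 log units; within the scatter), which stayed within the scatter, and compound 1, carrying a different group on the same core, also sits within the scatter of compound 2. Removing the chloro is therefore expected to give no step beyond the scatter in this assay. The estimate for compound 4 in this assay is 11000 nM, with a range from 6000 nM to 20000 nM. This estimate means an expected step of a 1.1-fold lower number from compound 2 to compound 4 (0.04 log units; within the scatter), within the scatter.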

Compound 4, half-maximal inhibitory concentration: 15000 nM
Compound 4: the middle estimate sits 1.4-fold (0.13 log units) below what was measured; low and high end bracket the measured number.
By their numbers in this assay, from the lowest: compounds 1, 3, 2 and 4 (each within the scatter of the next).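

In this assay, the aromatic carbon can now be read with no substituent at all: hydrogen in place of chloro gives a 1.3-fold higher number from compound 2 to compound 4 (0.10 log units; within the scatter), hydrogen in place of fluoro gives a 1.4-fold higher number from compound 3 to compound 4 (0.13 log units; within the scatter), and removing the methoxy group gives a 1.5-fold higher number from compound 1 to compound 4 (0.18 log units; within the scatter). The earlier compounds shown here compared only one substituent with another, whereas these steps show that removing the halogen altogether, not merely exchanging it, produces no step beyond the scatter. No measurement shown offers an explanation for this flat result.

From the compounds shown here alone, it remains open whether an amine, a carboxylic acid or a longer chain on this carbon would produce a step beyond the scatter. Also open, going by these compounds, is whether replacing the hydroxyl group on the shared core would do so.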